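This account rests on a few compounds, and the source may have more. Where it says the series, first, only, none or still open, it means among the compounds named here.

In an ADME assay on HepG2 2.2.15 cells (Homo sapiens) for cytotoxicity (a lower number here means that less compound is tolerated, a higher number that more compound is tolerated), three compounds have been measured so far:

Compound 1 `O=C(Nc1ncc(Cc2ccc(Cl)cc2)s1)c1ccc(F)cc1F` gives "not toxic" (no number reported).
Compound 2 `CC(C)(C)OC(=O)Nc1ncc(C(Oc2cccc(C#N)c2)c2ccc(Cl)cc2)s1` gives > 50000 nM, which is a limit of the assay, not a number.
Compound 3 `COCCCNc1ncc(C(Oc2ccc3cc(Br)ccc3c2)c2ccc(Cl)cc2)s1` gives "not toxic" (no number reported).

Compound 3 therefore stands without a single number; its entry is one of two without a number, and the third entry sits at the limit of > 50000 nM in this assay, at which 1 of the 3 values shown sits. Compound 4 `CCc1ccc(S(=O)(=O)Nc2ncc(C(Oc3ccc4cc(Br)ccc4c3)c3ccc(Cl)cc3)s2)cc1` differs from compound 3 in one place: (4-ethylphenyl)sulfonyl in place of 3-methoxypropyl on a nitrogen on an aromatic ring. Among the measured compounds shown here, no step between measured compounds is available, and all three measured entries point the same way, towards a compound that is tolerated. The change in this assay from compound 3 to compound 4 is expected to be none beyond the usual scatter. Compound 4 is estimated at 50000 nM, within 20000 nM to 200000 nM.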

Compound 4, half-maximal cytotoxic concentration: > 50000 nM
Compound 4: only a limit was reported (the forecaster's own chance of this, stated with the estimate: 70%); the middle value sits exactly at the limit.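

In this assay compound 4 gives > 50000 nM, which is a limit and not a number. Among the compounds shown here, compound 3 has no number either, so no step between compound 3 and compound 4 can be read. The compounds shown leave open what concentration, if any, would prove toxic to these cells.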